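The source may hold more compounds than are shown below. What is called first, only, known or untested is meant among the compounds shown, and "the series" means these compounds.

The series shares one core, carried by compound 1 `Cc1cc(CNC(C)(C)C)c(C)n1Nc1ccnc2cc(Cl)ccc12`, compound 2 `Cc1c(CN2CCCC2)cc(-c2ccc(Cl)cc2)n1Nc1ccnc2cc(Cl)ccc12`, compound 3 `Cc1c(CNC[C@@H]2CCCN3CCCC[C@H]23)cc(-c2ccccc2)n1Nc1ccnc2cc(Cl)ccc12` and the unmeasured compound 4 `Cc1c(CN2CCCC2)cc(-c2ccccc2)n1Nc1ccnc2cc(Cl)ccc12`. In an ADME assay on K562 cells (Homo sapiens) for cytotoxicity, read by MTT assay (on this read-out lower numbers stand for stronger inhibition and higher numbers for weaker inhibition), compound 1 gives "not determined" (no result reported). In this assay compound 2 likewise gives "not determined" (no result reported), so compound 2 stands without a single number, and it is one of two entries in this assay that lack one. Going by the values given here, the only number in this assay belongs to compound 3, which gives 1680 nM.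

The move from compound 2 to compound 4 is a single change: hydrogen in place of chloro on an aromatic carbon, which read one bond further out is 4-chlorophenyl to phenyl. Compound 2 carries no number in this assay. Among the compounds with values here, for this pair no step in this assay can be stated, and no size or direction of step is put forward beyond noting that the change is small in count. What can be said about compound 4 rests on compound 3, which shares the phenyl group and gives 1680 nM in this assay. On that ground compound 4 is expected to give about 3000 nM in this assay, with a range estimated from 800 nM to 12000 nM.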

Compound 4, half-maximal inhibitory concentration: 2920 nM
The estimate for compound 4 lay 1.0-fold (0.01 log units) above the measured number; low and high end bracket the measured number.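

In this assay the series now has its first readable step, a 1.7-fold higher number from compound 3 to compound 4 (0.24 log units; within the scatter), and it lies at the saturated chain carbon bound to an aromatic carbon. At that position, a group of 5 heavy atoms with one five-membered non-aromatic ring stands in place of a group of 12 heavy atoms with 2 six-membered non-aromatic rings, and the numbers of the two compounds cannot be told apart. No measurement shown here bears on this result, so no reason for it can be offered.

The change from 4-chlorophenyl to phenyl remains unresolved: compound 2 has no number in this assay, and the step from it to compound 4 cannot be read. Also open, from the compounds shown here alone, is what a morpholine ring or a carboxylic acid on that chain carbon, or fluoro in place of chloro on the aromatic carbon, would give in this assay.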